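Adding an isopropyl group to the carboxymethyl amide

This account rests on a few compounds, and the source may have more. Where it says the series, first, only, none or still open, it means among the compounds named here.

Compound 1 (`CCn1c(C(=O)NC(C)(C)CO)ccc1C(CC)(CC)c1ccc(OCS(=O)(=O)c2ccccc2)c(C)c1`) gives 20700 nM in a functional assay on MCF7 cells (Homo sapiens) for antiproliferative activity, read by MTT assay, with a stated time of 24 h (on this read-out lower numbers stand for stronger inhibition and higher numbers for weaker inhibition), and compound 2 (`CCn1c(C(=O)NCC(=O)O)ccc1C(CC)(CC)c1ccc(OCS(=O)(=O)c2ccccc2)c(C)c1`) gives 33100 nM there. Going by the values given here, these two values lie within the scatter of each other, so compound 2 stands level with the only other measured compound. Compound 3 (`CCn1c(C(=O)N[C@H](C(=O)O)C(C)C)ccc1C(CC)(CC)c1ccc(OCS(=O)(=O)c2ccccc2)c(C)c1`) has not yet been measured. Its difference from compound 2 is isopropyl in place of hydrogen on a saturated chain carbon bound to an amide-type nitrogen and a carbonyl carbon with isopropyl in place of hydrogen on a saturated chain carbon bound to an amide-type nitrogen and a carbonyl carbon. Among the compounds with values here, no measured step tests this exact change. The closest evidence is a 1.6-fold higher number from compound 1 to compound 2 (0.20 log units; within the scatter) for carboxymethyl in place of 1-(hydroxymethyl)-1-methylethyl on an amide-type nitrogen, a change at the same amide substituent. No shift beyond the scatter is therefore expected, and the estimated step is a 1.2-fold lower number from compound 2 to compound 3 (0.07 log units; within the scatter) in size. In this assay compound 3 is estimated at 28000 nM with an expected range from 12000 nM to 60000 nM as the likely span.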

Compound 3, half-maximal inhibitory concentration: 24500 nM
For compound 3 the middle estimate is 1.1-fold (0.06 log units) above the measured one; measured number inside the range.
By their numbers in this assay, from the lowest: compounds 1, 3 and 2 (each within the scatter of the next).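

In this assay, putting isopropyl in place of hydrogen on the saturated chain carbon bound to an amide-type nitrogen and a carbonyl carbon gives a 1.4-fold lower number from compound 2 to compound 3 (0.13 log units; within the scatter) and so leaves the number within the scatter. Replacing 1-(hydroxymethyl)-1-methylethyl on the amide-type nitrogen with 1-carboxy-2-methylpropyl gives a 1.2-fold higher number from compound 1 to compound 3 (0.07 log units; within the scatter) and also stays within the scatter, so all three amide substituents now stand level, where the earlier step had shown this for carboxymethyl alone. Nothing given here explains why these numbers stand level.

On these data alone, it remains open whether a longer chain or a phenyl ring in place of isopropyl on that carbon would move the number beyond the scatter. The same question holds for an amine in place of the carboxylic acid.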